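Terminal aryl variation on the benzimidazole-biphenyl series

The source may report more compounds than this note shows. Statements on the series, on what has been measured and on what is new or still open speak of the compounds shown alone.

Measured so far:
compound 1 `Cc1ccc2[nH]c(-c3ccc(-c4ccc(-c5cccc(Cl)c5)cc4)cc3)nc2c1` — 3600 nM
compound 2 `COc1ccc(-c2ccc(-c3ccc(-c4nc5cc(C)ccc5[nH]4)cc3)cc2)cc1OC` — 3510 nM

The two compounds share one core and differ only in the aryl group at the far end. In a functional assay on SiHa cells (Homo sapiens) for inhibition, read by sulforhodamine B assay (a lower number here means a stronger inhibitor of growth, a higher number a weaker inhibitor of growth), compound 1 gives 3600 nM and compound 2 gives 3510 nM. The step of a 1.0-fold lower number from compound 1 to compound 2 (0.01 log units; within the scatter) is flat, so compound 2 stands level with compound 1 on the numbers shown; the gap between them is within the scatter.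

Compound 3 `Cc1ccc2[nH]c(-c3ccc(-c4ccc(-c5ccccc5)cc4)cc3)nc2c1` has not been measured. Its difference from compound 2: phenyl in place of 3,4-dimethoxyphenyl on an aromatic carbon. Among the compounds with values here, the only step that bears on this position is the one from compound 1 to compound 2, which swapped the terminal aryl substituents and left the read-out unchanged, a 1.0-fold lower number from compound 1 to compound 2 (0.01 log units; within the scatter). On that basis a substituent-free phenyl at the same place is expected to behave alike, with no step beyond the scatter: the expected step is a 1.0-fold lower number from compound 2 to compound 3 (0.00 log units; within the scatter). The estimate for compound 3 in this assay is therefore 3500 nM, with a range of 1500 nM to 8000 nM.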

Compound 3, concentration for 50% growth inhibition: 35200 nM
The estimate for compound 3 lay 10-fold (1.00 log units) below the measured number, outside the stated range (above it).
By their numbers in this assay, from the lowest: compounds 2 and 1 (each within the scatter of the next); then compound 3.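

In this assay, the terminal aryl position proves sensitive to substitution: a 10-fold higher number from compound 2 to compound 3 (1.00 log units; beyond the scatter) when phenyl replaces 3,4-dimethoxyphenyl, and a 9.8-fold higher number from compound 1 to compound 3 (0.99 log units; beyond the scatter) when hydrogen replaces chloro. Within the data shown here, the earlier flat step, a 1.0-fold lower number from compound 1 to compound 2 (0.01 log units; within the scatter), therefore showed only that these two substituted rings are level with each other, not that the position tolerates any aryl group. Among these three compounds, both substituted terminal rings give lower numbers than the bare phenyl of compound 3, which is the weakest inhibitor of growth here, and no compound shown goes against that pattern, although no measurement shown accounts for the difference.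

The compounds shown leave open whether one substituent of any kind is enough to hold the lower number, since chloro and the two methoxy groups differ in identity, number and placement on the ring. A terminal ring carrying a single methoxy group, an amine or a carboxylic acid would test whether the level seen for compound 1 and compound 2 extends beyond these two substituted rings.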